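Swapping a large aryl group for bromo

The compounds below may be only part of what the source reports. "The series", "measured", "known", "first", "only" and "open" are said of these compounds alone.

For the measured compounds named here, in a functional assay on HCT-116 cells (Homo sapiens) for antiproliferative activity, read by CellTiter-Glo, with a stated time of 72 h (on this read-out lower numbers stand for stronger inhibition and higher numbers for weaker inhibition), compound 1 (`O=C(NO)c1ccc(/C=C/c2ccnc(-c3cccc(CO)c3)c2)cc1`) gives 1700 nM and holds the only true number so far. Compound 2 (`O=C(NO)c1ccc(/C=C/c2cccc(-c3cc(F)ccc3O)c2)cc1`) reads > 10000 nM and that is a limit of the assay, not a number. Compound 3 (`O=C(NO)c1ccc(/C=C/c2cc(-c3ccc(C(F)(F)F)cc3)ncc2F)cc1`) reads > 10000 nM and that too is a limit. The picture around compound 1 is therefore framed only by the limit of > 10000 nM in this assay, at which 2 of the 3 values shown sit, and by no finer measurement.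

Compound 4 (`O=C(NO)c1ccc(/C=C/c2ccnc(Br)c2)cc1`) keeps the core of compound 1 and changes one group (bromo in place of 3-(hydroxymethyl)phenyl on an aromatic carbon) with bromo in place of 3-(hydroxymethyl)phenyl on an aromatic carbon. Going by the values given here, no measured pair shows what such a swap does in this assay so the expectation is loose: a modest step toward weaker inhibition, only a little beyond the scatter. Among the compounds with values here, the sole numeric anchor is compound 1 at 1700 nM and the estimate stays near it. The estimated change (a 2.4-fold higher number from compound 1 to compound 4 (0.37 log units; beyond the scatter)) is small. For compound 4 the expected value is 4000 nM with an estimated range from 900 nM to 10000 nM overall.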

Compound 4, half-maximal inhibitory concentration: > 10000 nM
Compound 4 was reported as a limit; the forecaster's own chance of this, stated with the estimate: 25%; middle value at least 2.5-fold (0.39 log units) from the limit.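

Putting bromo in place of 3-(hydroxymethyl)phenyl, on the aromatic carbon next to the ring nitrogen, produces an at least 5.8-fold higher number from compound 1 to compound 4 (0.76 log units; beyond the scatter) in this assay. Compound 4 reads > 10000 nM, which is a limit of the assay and not a number. This is the first single change that can be read here, and it shows that the measurable activity of compound 1 does not survive when the aryl group at this place gives way to bromo, although the full size of the step stays unknown because the read-out ends at this limit: the limit of > 10000 nM in this assay, at which 3 of the 4 values shown sit.

The compounds shown leave open whether the ring itself or its hydroxymethyl group matters more, a question that a plain phenyl at this place could separate. As far as these compounds go, how an amine or a carboxylic acid in place of the hydroxymethyl would read in this assay is also open.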